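A few compounds are considered here, and "the series" means these few. Any claim that something is new, unique, unknown or untested is made for them only; others in the source may bear on it.

Compounds 1 and 2 carry the same brominated core and differ only in the chain on the aromatic nitrogen. Compound 1 is `Cc1nc2c(Br)c(Br)c(Br)c(Br)c2n1CC#N` and compound 2 is `Cc1nc2c(Br)c(Br)c(Br)c(Br)c2n1CCCC#N`. In a functional assay on CCRF-CEM cells (Homo sapiens) for cytotoxicity, read by MTT assay, with a stated time of 24 h, tested at 50 uM (on this read-out higher numbers stand for a weaker effect at the one concentration tested and lower numbers for a stronger effect), compound 1 gives 2%, and in the same assay compound 2 gives 1%. The one measured step, a number 1 percentage points lower from compound 1 to compound 2 (within the scatter), is within the scatter, so compound 2 stands alongside compound 1 on the numbers shown, with no difference that can be read as real.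

Compound 3 is `Cc1nc2c(Br)c(Br)c(Br)c(Br)c2n1CCC#N`. Relative to compound 2 the change is cyano in place of cyanomethyl on a saturated chain carbon, two bonds along the chain from an aromatic nitrogen. Among the measured compounds shown here, this is a shortening of the chain that ends in the nitrile, and the only step that bears on it is the lengthening from compound 1 to compound 2, which moved the number by a number 1 percentage points lower from compound 1 to compound 2 (within the scatter). Since compound 3 sits between compound 1 and compound 2 in chain length, and both of those give numbers within the scatter of each other, no step beyond the scatter is expected in this assay for compound 3; the expected step is a number 1 percentage points higher from compound 2 to compound 3 (within the scatter). The estimate for compound 3 is therefore 2%, with a range from 0% to 10%.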

Compound 3, a percentage reported as activity, at one concentration (the size of the read-out at that concentration, not a potency): 2%
Estimate against measurement, compound 3: no gap at the digits printed; low and high end bracket the measured number.
By their numbers in this assay, from the lowest: compounds 2, 1 and 3 (each within the scatter of the next).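

With 2-cyanoethyl in place, the three nitrile chains on the aromatic nitrogen can now be read together in this assay: shortening 3-cyanopropyl to 2-cyanoethyl gives a number 1 percentage points higher from compound 2 to compound 3 (within the scatter) and extending cyanomethyl to 2-cyanoethyl gives no change at the digits printed from compound 1 to compound 3 (within the scatter), so the middle chain stands apart from neither of the other two. Among the compounds shown here, the single earlier step compared only the two outer chains; across cyanomethyl, 2-cyanoethyl and 3-cyanopropyl on the shared core, no step at this position can now be read as real, and this holds for these three compounds only. No independent measurement is available to explain this flat result.

As far as these compounds go, whether the same picture holds when the nitrile at the chain end gives way to a carboxylic acid or a primary amine, or when the chain runs longer than 3-cyanopropyl, remains open. A read-out at one concentration is also not a potency, so any separation among these three compounds at lower concentrations remains open as well.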